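This account rests on a few compounds, and the source may have more. Where it says the series, first, only, none or still open, it means among the compounds named here.

Compound 2 `CC(C)=CC[C@@H](OC(=O)C1CCCCO1)C1=CC(=O)c2c(O)ccc(O)c2C1=O` carries an ester on an oxygen on a saturated carbon of the shared core. In a functional assay on HeLa cells (Homo sapiens) for cytotoxicity, read by MTT assay (a lower number here means a stronger inhibitor, a higher number a weaker inhibitor), compound 2 gives only a limit, > 100000 nM. Going by the values given here, its one measured neighbour is compound 1 `COC(C)CO[C@H](CC=C(C)C)C1=CC(=O)c2c(O)ccc(O)c2C1=O`, in which that oxygen carries a 2-methoxypropyl group in place of the ester; in this assay compound 1 gives 53400 nM. Among the compounds with values here, the single measured step, an at least 1.8-fold higher number from compound 1 to compound 2 (0.27 log units; that floor lies within the scatter), shows only that the ester does not make the compound stronger, and the two values cannot be told apart with confidence. Compound 3 `CCC(O)(CC)CC(=O)O[C@H](CC=C(C)C)C1=CC(=O)c2c(O)ccc(O)c2C1=O` keeps the ester but changes what sits on the carbonyl carbon: 2-ethyl-2-hydroxybutyl in place of oxan-2-yl on a carbonyl carbon. Within the data shown here, no measured step addresses an exchange of this kind, and the only evidence is the limit of > 100000 nM in this assay, at which 1 of the 2 values shown sits. A change of modest size in this assay is therefore expected, with no clear direction, and the expected step is a number no higher from compound 2 to compound 3 (the limit leaves the size open). Compound 3 is estimated at 100000 nM, within a range from 40000 nM to 250000 nM.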

Compound 3, half-maximal inhibitory concentration: 52000 nM
Compound 3: the middle estimate sits 1.9-fold (0.28 log units) above what was measured, and the stated range covers the measured number.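

In this assay, putting 2-ethyl-2-hydroxybutyl in place of oxan-2-yl on the carbonyl carbon gives an at least 1.9-fold lower number from compound 2 to compound 3 (0.28 log units; that floor lies within the scatter), so this floor alone does not separate the two esters. Compound 2 remains a limit of the assay and not a number, which leaves the true size of this step unknown: the limit of > 100000 nM in this assay, at which 1 of the 3 values shown sits. Going by these compounds alone, what is new comes from the comparison with the 2-methoxypropyl group, a 1.0-fold lower number from compound 1 to compound 3 (0.01 log units; within the scatter): an ester on this oxygen can give a measured number inside the range of the assay, and that number cannot be told apart from the one for compound 1.

The exchange from compound 2 to compound 3 removes a ring and adds a hydrogen-bond donor in a single step, so the compounds shown leave open whether either difference matters on its own. They also leave open how this assay would read with an amine, a carboxylic acid or a plain longer chain, such as an unbranched hexyl group, on the same carbonyl carbon.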